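The source may report more compounds than this note shows. Statements on the series, on what has been measured and on what is new or still open speak of the compounds shown alone.

In a functional assay on QG-56 cells (Homo sapiens) for antiproliferative activity (on this read-out lower numbers stand for stronger inhibition and higher numbers for weaker inhibition), compound 1 `Cn1cncc1C(O)(c1ccc(C#N)cc1)c1cc2cc([N+](=O)[O-])cc(-c3ccc(C#N)cc3)c2o1` gives 32.6 nM, compound 2 `Cn1cncc1C(O)(c1ccc(C#N)cc1)c1cc2cc([N+](=O)[O-])cc(-c3ccc(F)cc3)c2o1` gives 158 nM, and compound 3 `Cn1cncc1C(O)(c1ccc(C#N)cc1)c1cc2cc([N+](=O)[O-])cc(-c3cccc(F)c3)c2o1` gives 145 nM. Compound 3 thus stands within the scatter of compound 2, and both lie on the weaker side of compound 1. Compound 4 `Cc1cccc(-c2cc([N+](=O)[O-])cc3cc(C(O)(c4ccc(C#N)cc4)c4cncn4C)oc23)c1` has methyl in place of fluoro on an aromatic carbon, meta to a large group (methyl in place of fluoro on an aromatic carbon). For the measured compounds named here, no measured step makes this swap. The nearest evidence is a 1.1-fold lower number from compound 2 to compound 3 (0.04 log units; within the scatter), within the scatter, while the larger steps, a 4.8-fold higher number from compound 1 to compound 2 (0.69 log units; beyond the scatter) and a 4.4-fold higher number from compound 1 to compound 3 (0.65 log units; beyond the scatter), both remove the cyano group. Little movement is therefore expected in this assay. The estimated step is a 1.0-fold higher number from compound 3 to compound 4 (0.01 log units; within the scatter), none beyond the scatter. Compound 4 is expected at 150 nM, within an estimated range of 70 nM to 320 nM.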

Compound 4, half-maximal inhibitory concentration: 23.2 nM
Estimate against measurement, compound 4: 6.5-fold (0.81 log units) above; measured number outside the range, below it.
By their numbers in this assay, from the lowest: compounds 4 and 1 (each within the scatter of the next); then compounds 3 and 2 (each within the scatter of the next).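

In this assay the aromatic carbon meta to a large group proves sensitive to the swap itself, with a 6.3-fold lower number from compound 3 to compound 4 (0.80 log units; beyond the scatter) on going from fluoro to methyl and a 6.8-fold lower number from compound 2 to compound 4 (0.83 log units; beyond the scatter) for 3-methylphenyl in place of 4-fluorophenyl. For the compounds shown here, the earlier compounds showed only that the two fluorophenyl groups stood within the scatter of each other and that both were weaker than 4-cyanophenyl. Here a cyano group proves unnecessary for the low number, since a 1.4-fold lower number from compound 1 to compound 4 (0.15 log units; within the scatter) stays within the scatter. Nothing available explains why methyl outperforms fluoro here. Going by these compounds, whether an ethyl chain, a methoxy group or an amine in place of the methyl would keep the number as low stays open.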